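Cytotoxicity limits for two compounds and a third

The source may hold more compounds than are shown below. What is called first, only, known or untested is meant among the compounds shown, and "the series" means these compounds.

Compound 1 `Cc1cc(=O)oc2cc(OCC(O)CN3CCC(C(N)=O)CC3)ccc12` — > 100000 nM
Compound 2 `Cc1c(Cc2ccc(Br)cc2)c(=O)oc2cc(OCC(O)CN3CCC(C(N)=O)CC3)ccc12` — > 100000 nM

Both were tested in an ADME assay on A549 cells (Homo sapiens) for cytotoxicity, read by CellTiter-Glo; on this read-out higher numbers stand for lower toxicity in this test and lower numbers for higher toxicity in this test. For compound 1 the value > 100000 nM is a limit of the test, not a number. For compound 2 the value > 100000 nM is likewise a limit. For the measured compounds named here, compound 2 thus stands at the limit, alongside the only other value shown, which is also a limit. The step that the two limits leave unreadable from compound 1 to compound 2 cannot be read, since the limit of > 100000 nM in this assay, at which 2 of the 2 values shown sit, holds both of its ends.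

Compound 3 `COc1ccc(Cc2c(C)c3ccc(OCC(O)CN4CCC(C(N)=O)CC4)cc3oc2=O)c(Br)c1` differs from compound 2 in one place: 2-bromo-4-methoxyphenyl in place of 4-bromophenyl on a saturated chain carbon bound to an aromatic carbon. Going by the values given here, the single measured step bears on this change only by showing two limits, so no size can be drawn from it. The step expected in this assay is a step that the limit leaves unreadable from compound 2 to compound 3, meaning no change beyond the scatter, with the result expected to stay a limit. Compound 3 is estimated at 150000 nM with a range from 60000 nM to 400000 nM.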

Compound 3, half-maximal cytotoxic concentration: 44400 nM
The estimate for compound 3 lay 3.4-fold (0.53 log units) above the measured number; the whole stated range lies above it.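

For the compounds shown here, compound 3 is the first of the three to give a number rather than a limit in this assay, which shows that a change at this place can register as higher toxicity in this test. Replacing 4-bromophenyl with 2-bromo-4-methoxyphenyl gives an at least 2.2-fold lower number from compound 2 to compound 3 (0.35 log units; beyond the scatter), and placing 2-bromo-4-methoxybenzyl on the hydrogen-bearing aromatic carbon of the core of compound 1 gives an at least 2.2-fold lower number from compound 1 to compound 3 (0.35 log units; beyond the scatter). The step between compound 1 and compound 2 cannot be read, as each of them gives only a limit of the test: the limit of > 100000 nM in this assay, at which 2 of the 3 values shown sit.

The compounds shown do not separate the added methoxy group from the changed place of the bromine, as both differ together in compound 3. As far as these compounds go, how an amine or a carboxylic acid on this ring would read in this test also stays open.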